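The compounds below may be only part of what the source reports. "The series", "measured", "known", "first", "only" and "open" are said of these compounds alone.

The measured compounds:

compound 1, `COc1ccc(/C=C2\CCC/C(=C\c3cccc([N+](=O)[O-])c3)C2=O)cc1`: 10.4 ug/mL
compound 2, `COc1cccc(/C=C2\CCC/C(=C\c3cccc([N+](=O)[O-])c3)C2=O)c1`: 4.94 ug/mL

In a functional assay on SK-N-MC cells (Homo sapiens) for cytotoxicity, read by MTT assay (on this read-out higher numbers stand for weaker inhibition and lower numbers for stronger inhibition), compound 2 gives 4.94 ug/mL, the lowest of the two numbers recorded; its nearest neighbour is compound 1 with 10.4 ug/mL. Within the data shown here, the only step between measured compounds is a 2.1-fold lower number from compound 1 to compound 2 (0.32 log units; beyond the scatter), a change in where the single methoxy group sits on the ring rather than the addition of a second one.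

Compound 3, `COc1cccc(/C=C2\CCC/C(=C\c3cccc([N+](=O)[O-])c3)C2=O)c1OC`, differs from compound 2 by methoxy in place of hydrogen on an aromatic carbon. Among the measured compounds shown here, no measured pair shows a second methoxy group entering beside an existing one, so the one available step bears on this change only loosely: it shows that moving a methoxy group on this ring shifts the number modestly, and gives no sign of a large swing in either direction. The account therefore expects for compound 3 a step of about a 1.0-fold higher number from compound 2 to compound 3 (0.01 log units; within the scatter), that is, no change beyond the scatter in this assay. The estimate for compound 3 is 5 ug/mL, within a range from 2.5 ug/mL to 10 ug/mL.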

Compound 3, half-maximal inhibitory concentration: 10.1 ug/mL
Compound 3: the middle estimate sits 2.0-fold (0.31 log units) below what was measured; measured number outside the range, above it.
By their numbers in this assay, from the lowest: compound 2; then compounds 3 and 1 (each within the scatter of the next).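

In this assay, a methoxy group entering on this aromatic carbon, ortho to a large group and ortho to a methoxy group, does not leave the number unchanged: the outcome is a 2.0-fold higher number from compound 2 to compound 3 (0.31 log units; beyond the scatter) and thus a modest move toward weaker inhibition. The earlier step concerned only where a single methoxy group sits on the ring, whereas this one shows that a second methoxy group at this position also shifts the number beyond the scatter. Nothing available explains the shift, so the result gives its size and direction but no cause.

The compounds shown leave open whether this step belongs to methoxy in particular or would also follow from another group on the same aromatic carbon, such as a hydroxyl group, a fluorine atom or an amine. They also leave open how the number responds to changes on the other aromatic ring, since the nitro group there stays the same in all three compounds and no replacement such as a nitrile or a carboxylic acid appears.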